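Series notes: defining the stereocentre of compound 1

A few compounds are considered here, and "the series" means these few. Any claim that something is new, unique, unknown or untested is made for them only; others in the source may bear on it.

The shared core carries a side chain on its aromatic nitrogen that varies across the set. Compound 1 `O=C1c2c[n+]([O-])c3ccccc3c2C(=O)c2c1c1ccccc1n2Cc1cn(CC(O)CO)nn1` serves as the reference point; in a functional assay on A-375 cells (Homo sapiens) for cytotoxicity, read by MTT assay, with a stated time of 72 h (on this read-out lower numbers stand for stronger inhibition and higher numbers for weaker inhibition), compound 1 gives 440 nM. Compound 2 `O=C1c2c[n+]([O-])c3ccccc3c2C(=O)c2c1c1ccccc1n2Cc1cn([C@@H]2O[C@H](CO)[C@@H](O)[C@H](O)[C@H]2O)nn1` gives 230 nM, and compound 3 `O=C1c2c[n+]([O-])c3ccccc3c2C(=O)c2c1c1ccccc1n2CCCN1CCC(O)CC1` gives 240 nM. Compound 1 holds the highest of the three numbers, although neither neighbour is separated from it beyond the scatter: a 1.9-fold lower number from compound 1 to compound 2 (0.28 log units; within the scatter) and a 1.8-fold lower number from compound 1 to compound 3 (0.26 log units; within the scatter). Both of those steps exchange whole side-chain groups and still move the number only within the usual scatter.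

Compound 4 `O=C1c2c[n+]([O-])c3ccccc3c2C(=O)c2c1c1ccccc1n2Cc1cn(C[C@H](O)CO)nn1` differs from compound 1 as follows: the two compounds have the same atoms and bonds; at least one stereo element is drawn with a configuration in one of them and without one in the other: 1 of 1 stereo elements differ; a stereocentre at a saturated chain carbon is drawn without a configuration in compound 1 and S in compound 4. Going by the values given here, no measured step bears directly on a change of drawn configuration alone; the two steps that start from compound 1 swap far larger pieces and stayed within the scatter. Nothing in the set points to a particular direction for the defined configuration. The expected step of a 1.1-fold lower number from compound 1 to compound 4 (0.04 log units; within the scatter) is therefore none beyond the scatter. Compound 4 is estimated at 400 nM in this assay, with a range from 200 nM to 800 nM.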

Compound 4, half-maximal inhibitory concentration: 350 nM
Estimate against measurement, compound 4: 1.1-fold (0.06 log units) above, within the range that was stated.
By their numbers in this assay, from the lowest: compounds 2, 3, 4 and 1 (each within the scatter of the next).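

In this assay the step is a 1.3-fold lower number from compound 1 to compound 4 (0.10 log units; within the scatter), and the pair is separated by one thing only: the fact that one of compounds 1 and 4 is drawn with a defined configuration and the other without, at the place where they differ

Going by these compounds alone, this is the one step in the set that isolates the drawn configuration at this saturated chain carbon, and it stays within the scatter, as do the exchanges of whole side-chain groups. With the S configuration defined, those exchanges read the same way: 1-(2,3-dihydroxypropyl)-1H-1,2,3-triazol-4-yl in place of 2-(4-hydroxypiperidin-1-yl)ethyl gives a 1.5-fold higher number from compound 3 to compound 4 (0.16 log units; within the scatter), and 2,3-dihydroxypropyl in place of 3,4,5-trihydroxy-6-(hydroxymethyl)oxan-2-yl gives a 1.5-fold higher number from compound 2 to compound 4 (0.18 log units; within the scatter), so compound 4 is not separated from either neighbour.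

The compounds shown leave open how the R configuration at this carbon would read against the S configuration of compound 4, as compound 1 carries no defined configuration. Also open, on these data alone, is whether a carboxylic acid, a primary amine or a longer chain in place of the 2,3-dihydroxypropyl group would move the number beyond the scatter.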